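The source may hold more compounds than are shown below. What is called first, only, known or untested is meant among the compounds shown, and "the series" means these compounds.

Of the compounds shown here, three built on one shared core have been tested in a functional assay on the whole organism with Scenedesmus acutus as the target, read by spectrophotometry; a higher number here means a weaker inhibitor, a lower number a stronger inhibitor. Compound 1 `COC(=O)CSc1cc(/N=c2\sc(=S)n3n2CCCC3)c(F)cc1Cl` gives 191 nM in this assay and stands second highest of the three numbers. Compound 3 `Fc1cc(Cl)ccc1-n1c(=S)n2n(c1=S)CCCC2` gives 18.2 nM, a number beyond the scatter below that of compound 1, while compound 2 `S=c1n(-c2ccccc2)c(=S)n2n1CCCC2` gives 6310 nM, beyond the scatter above it. Compound 4 `CC(C)Oc1cc(/N=c2\sc(=S)n3n2CCCC3)c(F)cc1Cl` has not been measured yet. It differs from compound 1 in a single place: isopropoxy in place of ((methoxycarbonyl)methyl)sulfanyl on an aromatic carbon. Going by the values given here, no pair of measured compounds shows this particular change, so the size and direction of the step can only be guessed. A small step in this assay, not clearly beyond the scatter, is expected: a 1.3-fold lower number from compound 1 to compound 4 (0.10 log units; within the scatter). Compound 4 is therefore estimated at 150 nM, within a range from 40 nM to 700 nM.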

Compound 4, half-maximal inhibitory concentration: 11.2 nM
Compound 4: middle estimate off by 13-fold (1.13 log units), on the high side; measured number outside the range, below it.
By their numbers in this assay, from the lowest: compounds 4 and 3 (each within the scatter of the next); then compound 1; then compound 2.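

In this assay, placing isopropoxy instead of ((methoxycarbonyl)methyl)sulfanyl on this aromatic carbon, ortho to the chloro group and para to the fluoro group, gives a 17-fold lower number from compound 1 to compound 4 (1.23 log units; beyond the scatter), a large step. The group at this position can therefore change the result strongly, and here the group with fewer heavy atoms goes with the stronger inhibitor. No measurement shown accounts for this step. Going by these compounds alone, with only two groups compared here, it remains open whether the ether oxygen, the branched chain or the loss of the ester matters most. A methoxy group, a longer chain or a carboxylic acid at this position could help separate these possibilities.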